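This account rests on a few compounds, and the source may have more. Where it says the series, first, only, none or still open, it means among the compounds named here.

Measured so far:
- compound 1, `COc1cc(-c2cc(/C=C/C(=O)c3ccc(Cl)c(Cl)c3)[nH]n2)cc(OC)c1OC` — 105%
- compound 2, `COc1ccc(-c2cc(/C=C/C(=O)c3ccc(N)cc3)[nH]n2)cc1OC` — 93%
- compound 3, `COc1ccc(-c2cc(/C=C/C(=O)c3ccc(N)cc3)[nH]n2)cc1` — 105%

In a functional assay on ACHN cells (Homo sapiens) for cytotoxicity, read by sulforhodamine B assay, with a stated time of 48 h, tested at 0.1 uM (a higher number here means a weaker effect of the compound at the concentration tested, a lower number a stronger effect), compound 1 stands level with compound 3 at the digits shown, and the two share the highest value of the three; compound 2 gives 93% and sits lower, a gap that lies outside the usual scatter. Within the data shown here, the single measured step, a number 12 percentage points higher from compound 2 to compound 3 (beyond the scatter), concerns hydrogen in place of methoxy on an aromatic carbon and runs toward weaker effect, a modest move.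

Compound 4, `COc1ccc(C(=O)/C=C/c2cc(-c3cc(OC)c(OC)c(OC)c3)n[nH]2)cc1OC`, is not yet measured. It differs from compound 1 in that (3,4-dimethoxyphenyl in place of 3,4-dichlorophenyl on a carbonyl carbon). Among the measured compounds shown here, no measured pair changes the group on the carbonyl carbon, so the step from compound 2 to compound 3 bears on it only loosely, as a sign that a methoxy-bearing ring can move the number by a modest amount. All three measured values lie at or near no effect, and compound 1 itself is at the top of that range. A step of no more than modest size is therefore expected, with no clear direction, giving a number 5 percentage points lower from compound 1 to compound 4 (within the scatter). Compound 4 is estimated at 100% in this assay, between 85% and 115%.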

Compound 4, a percentage reported as activity, at one concentration (the size of the read-out at that concentration, not a potency): 97%
Estimate against measurement, compound 4: 3 percentage points above, within the range that was stated.
By their numbers in this assay, from the lowest: compounds 2, 4, 1 and 3 (each within the scatter of the next, the first and the last beyond it).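

In this assay, among these compounds, a number 8 percentage points lower from compound 1 to compound 4 (within the scatter) gives the first reading at the group on the carbonyl carbon, where 3,4-dimethoxyphenyl stands in place of 3,4-dichlorophenyl. At this single concentration, the exchange of two chlorine atoms for two methoxy groups does not separate compound 4 from compound 1, although the entering group adds hydrogen-bond acceptors and heavy atoms. No measurement of any property of these groups bears on this result.

As far as these compounds go, a single concentration gives no potency, so any difference between compound 1 and compound 4 at higher concentrations remains open. Also open, from the compounds shown here alone, is how a phenyl bearing a carboxylic acid or a nitrile would read on the same carbonyl carbon in this assay.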